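Cyano in place of fluoro on the shared core

The compounds below may be only part of what the source reports. "The series", "measured", "known", "first", "only" and "open" are said of these compounds alone.

In a physicochemical assay for lipophilicity, using the shake flask method, measured as octanol-water partition, with a stated time of 30 min, at pH 7.4 (a lower number here means a more polar compound, a higher number a more lipophilic compound), compound 1 (`O=C(O)CCc1ccc(-c2ccc3cnn(-c4ccccn4)c3c2)cc1`) gives 2.4, compound 2 (`Cc1cc(-c2ccc(CCC(=O)O)cc2)cc2c1cnn2-c1ccccn1`) gives 2.6 and compound 3 (`O=C(O)CCc1ccc(-c2cc(F)c3cnn(-c4ccccn4)c3c2)cc1`) gives 2.8. Methyl in place of hydrogen gives a number 0.20 log units higher from compound 1 to compound 2 (within the scatter). Fluoro in place of hydrogen gives a number 0.40 log units higher from compound 1 to compound 3 (beyond the scatter). Fluoro in place of methyl gives a number 0.20 log units higher from compound 2 to compound 3 (within the scatter). Compound 3 therefore stands apart from compound 1 but cannot be separated from compound 2.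

Compound 4 (`N#Cc1cc(-c2ccc(CCC(=O)O)cc2)cc2c1cnn2-c1ccccn1`) carries cyano in place of fluoro on an aromatic carbon, ortho to a fused ring and meta to a large group: cyano in place of fluoro on an aromatic carbon. Compound 2 carries its methyl on this same carbon, so all three measured steps bear on the change. None of them involves a nitrile, however, and what cyano does here remains unmeasured.

The nearest guide is the fluoro step, which is the only one beyond the scatter. Removing the fluoro would point back towards compound 1 at 2.4, and the working assumption is that cyano lands near that level. The expected change is a number 0.50 log units lower from compound 3 to compound 4 (beyond the scatter), a modest fall that carries real uncertainty. For compound 4 the estimated value is 2.3, with an expected range of 1.9 to 2.7.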

Compound 4, distribution coefficient: 2.2
Beside the measured number, compound 4's estimate is 0.10 log units above it; measured number inside the range.
By their numbers in this assay, from the lowest: compounds 4, 1, 2 and 3 (each within the scatter of the next, the first and the last beyond it).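

In this assay, for the compounds shown here, cyano in place of fluoro gives a number 0.60 log units lower from compound 3 to compound 4 (beyond the scatter) and cyano in place of methyl gives a number 0.40 log units lower from compound 2 to compound 4 (beyond the scatter) on the same aromatic carbon, so a change at this position can also bring a clearly lower number, where the only earlier step beyond the scatter, fluoro in place of hydrogen, brought a higher one. Cyano in place of hydrogen gives a number 0.20 log units lower from compound 1 to compound 4 (within the scatter) and so leaves the nitrile inseparable from the hydrogen of compound 1 at this carbon, whereas the fluoro of compound 3 stands apart from that hydrogen. The compounds shown come with no measurement that would account for these steps.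

Still open, on these data alone, is how other groups on this carbon, such as an amine, a methoxy group or a carboxylic acid, would sit against the four numbers now in hand. Also open is whether cyano in place of hydrogen on another aromatic carbon of the shared core would again stay within the scatter, since all the substituents shown occupy this single carbon.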